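The compounds below may be only part of what the source reports. "The series", "measured", "known", "first", "only" and "open" are said of these compounds alone.

Compound 1 `Cc1nnc(-c2ccc(N3CCC(Oc4ccccc4C(F)(F)F)CC3)nn2)s1` is the reference point of this series. In an assay on microsomes from liver for inhibition of acyl-CoA desaturase 1 (Rattus norvegicus) (a higher number here means a weaker inhibitor, a lower number a stronger inhibitor), compound 1 gives 2.3 nM, the lowest of the three numbers recorded. Compound 3 `FC(F)(F)c1cccc(OC2CCN(c3ccc(-n4ccnc4)nn3)CC2)c1` gives 19 nM in this assay, a number beyond the usual scatter from that of compound 1. Compound 2 `c1cc(OC2CCN(c3ccc(-n4ccnc4)nn3)CC2)c2cc[nH]c2c1` gives 162 nM in this assay, the highest of the three and far from compound 1. These two comparisons are not single-point changes, so they show only where each compound lands.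

For the measured compounds named here, the untested compound 4 `O=C(NCCC1CC1)c1ccc(N2CCC(Oc3ccccc3C(F)(F)F)CC2)nn1` keeps the core of compound 1 and changes one group: (2-cyclopropylethyl)carbamoyl in place of 5-methyl-1,3,4-thiadiazol-2-yl on an aromatic carbon No direct precedent for this exchange exists among the measured compounds. The author expects a modest loss of inhibition, a step from compound 1 to compound 4 of about a 3.5-fold higher number from compound 1 to compound 4 (0.54 log units; beyond the scatter) in this assay, somewhat beyond the scatter. Compound 4 is therefore estimated at 8 nM in this assay, with a plausible range from 2 nM to 40 nM.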

Compound 4, half-maximal inhibitory concentration: 14 nM
For compound 4 the middle estimate is 1.8-fold (0.24 log units) below the measured one, within the range that was stated.
By their numbers in this assay, from the lowest: compound 1; then compounds 4 and 3 (each within the scatter of the next); then compound 2.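

For the compounds shown here, the step of a 6.1-fold higher number from compound 1 to compound 4 (0.78 log units; beyond the scatter) in this assay is the first single-point change, and it gives the first direct reading at this position, on an aromatic carbon para to a large group. The five-membered aromatic ring with 3 hetero atoms can be replaced there by (2-cyclopropylethyl)carbamoyl, which has no aromatic ring, at a modest cost in inhibition, so that ring is not essential to activity in this assay. Nothing available here bears on why the exchange costs inhibition.

With a single amide at this position, the separate contributions of the carbonyl, the amide hydrogen, the two-carbon link and the cyclopropyl ring remain unresolved. As far as these compounds go, it also remains open how a shorter chain on the amide nitrogen, a tertiary amide or a carboxylic acid would fare here.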